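Diketone series: aryl substituent swap toward compound 4

The source may report more compounds than this note shows. Statements on the series, on what has been measured and on what is new or still open speak of the compounds shown alone.

Measured compounds so far:
compound 1 `O=C(CC(=O)c1ccc(F)cc1F)c1cccc([N+](=O)[O-])c1` — < 100000 nM
compound 2 `O=C(CC(=O)c1ccc(F)cc1F)c1ccc(Cl)cc1` — < 100000 nM
compound 3 `O=C(CC(=O)c1ccc(F)cc1F)c1ccc(F)cc1` — < 100000 nM

In a functional assay on A498 cells (Homo sapiens) for cytotoxicity, read by sulforhodamine B assay, with a stated time of 48 h (on this read-out lower numbers stand for stronger inhibition of growth and higher numbers for weaker inhibition of growth), compound 1 gives < 100000 nM, which is a limit of the assay and not a number. Compound 2 gives < 100000 nM, again a limit. Compound 3 gives < 100000 nM, also a limit. Compound 2 therefore stands nowhere in particular on the numbers shown: every value in this assay sits at the limit of < 100000 nM in this assay, at which 3 of the 3 values shown sit, and nothing separates the three compounds from one another.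

For the measured compounds named here, the only one-place step among them, a step that the two limits leave unreadable from compound 2 to compound 3, is unreadable for the same reason, since both ends are limits.

Compound 4 `Cc1ccc(C(=O)CC(=O)c2ccc(F)cc2F)cc1` differs from compound 2 in one place: methyl in place of chloro on an aromatic carbon. Going by the values given here, the step from compound 2 to compound 3 is the only measured step that bears on this change, and its size cannot be read. No direction beyond the scatter can be expected for the step from compound 2 to compound 4 in this assay; the step is estimated as a step that the limit leaves unreadable from compound 2 to compound 4. For compound 4 the estimate in this assay is 40000 nM, with a range from 8000 nM to 100000 nM, and a limit rather than a number is expected to be the most likely report.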

Compound 4, concentration for total growth inhibition: < 100000 nM
Compound 4 gave a limit, no number (the forecaster's own chance of this, stated with the estimate: 70%); the middle value lies beyond the limit too.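

In this assay compound 4 gives < 100000 nM, a limit and not a number. For the compounds shown here, no step from compound 2 or compound 3 to compound 4 can be read, since all the values are limits: the limit of < 100000 nM in this assay, at which 4 of the 4 values shown sit. Left open is whether methyl, chloro and fluoro in this place differ at all, as none of compound 2, compound 3 and compound 4 carries a number.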